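Chain Lengthening in a Series of Triazole Ureas

The source may hold more compounds than are shown below. What is called first, only, known or untested is meant among the compounds shown, and "the series" means these compounds.

Measured compounds:
compound 1, `CCCCCCCCN1NN=C(NC(=O)Nc2c(C(C)C)cccc2C(C)C)N1`, 59 nM
compound 2, `CCCCCCCCCCN1NN=C(NC(=O)Nc2c(C(C)C)cccc2C(C)C)N1`, 14 nM
compound 3, `CCCCCCCCCCCCCCN1NN=C(NC(=O)Nc2c(C(C)C)cccc2C(C)C)N1`, 12 nM

Of the compounds shown here, three sharing one core have been tested in an assay on microsomes from intestine for inhibition of acyl-CoA:cholesterol acyltransferase (Oryctolagus cuniculus); a lower number here means a stronger inhibitor, a higher number a weaker inhibitor. Compound 1 gives 59 nM, compound 2 gives 14 nM and compound 3 gives 12 nM.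

The change from compound 1 to compound 2 is ethyl in place of hydrogen on a saturated chain carbon, eight bonds along the chain from an amine nitrogen in a ring and it made a step of a 4.2-fold lower number from compound 1 to compound 2 (0.62 log units; beyond the scatter). The core of compound 3 differs from that of compound 1 by hexyl in place of hydrogen on a saturated chain carbon, eight bonds along the chain from an amine nitrogen in a ring, a change that made a step of a 4.9-fold lower number from compound 1 to compound 3 (0.69 log units; beyond the scatter). Between compound 2 and compound 3 the step is a 1.2-fold lower number from compound 2 to compound 3 (0.07 log units; within the scatter), so the two are not told apart in this assay.

Compound 4, `CCCCCCCCCCCCCCCCN1NN=C(NC(=O)Nc2c(C(C)C)cccc2C(C)C)N1`, has not yet been measured. It differs from compound 3 by ethyl in place of hydrogen on a saturated chain carbon, ten or more bonds along the chain from an amine nitrogen in a ring. This is the same kind of change as from compound 1 to compound 2, though not at the same place along the chain. Since the step of a 1.2-fold lower number from compound 2 to compound 3 (0.07 log units; within the scatter) stayed within the scatter, a further lengthening is expected to make a step of about no change at the digits printed from compound 3 to compound 4 (within the scatter) from compound 3 to compound 4 in this assay. Compound 4 is therefore estimated at 12 nM, within 5 nM to 30 nM.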

Compound 4, half-maximal inhibitory concentration: 57 nM
For compound 4 the middle estimate is 4.8-fold (0.68 log units) below the measured one, and the stated range ends below it.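

In this assay the new step is a 4.8-fold higher number from compound 3 to compound 4 (0.68 log units; beyond the scatter), so ethyl in place of hydrogen on a saturated chain carbon did not carry over from the shorter chain to the longer one, and the two steps run in opposite directions: the same change on two cores in this assay, a 4.2-fold lower number (0.62 log units; beyond the scatter) from compound 1 to compound 2 and a 4.8-fold higher number (0.68 log units; beyond the scatter) from compound 3 to compound 4, 20-fold (1.30 log units) apart, beyond the scatter of two such steps The larger extension, hexyl in place of hydrogen, behaves the same way, with a 4.1-fold higher number from compound 2 to compound 4 (0.61 log units; beyond the scatter) standing against the earlier step in the other direction: the same change on two cores in this assay, a 4.9-fold lower number (0.69 log units; beyond the scatter) from compound 1 to compound 3 and a 4.1-fold higher number (0.61 log units; beyond the scatter) from compound 2 to compound 4, 20-fold (1.30 log units) apart, beyond the scatter of two such steps With a 1.0-fold lower number from compound 1 to compound 4 (0.01 log units; within the scatter), compound 1 and compound 4 are not told apart, which shows that the outcome of adding to the chain depends on the chain already present, but it does not show why, nor how the change would behave on a core that differs anywhere other than in the chain.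

The compounds shown leave open how a chain of a length lying between those of compound 3 and compound 4 would stand in this assay, and whether a still longer chain would take the number higher again. Also open is how a branched chain, or a chain ending in a carboxylic acid or an amine, would compare with the straight chains shown here.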